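Dropping the Ethoxycarbonyl Group: From Compound 2 to Compound 3

This account rests on a few compounds, and the source may have more. Where it says the series, first, only, none or still open, it means among the compounds named here.

Of the compounds shown here, two with a shared core have been measured so far. Compound 1 `O=C(OC1(C(=O)Nc2ccc([N+](=O)[O-])cc2)CCCCC1)c1ccccc1I` carries an iodo group on an aromatic carbon, and in a functional assay on MCF7 cells (Homo sapiens) for inhibition, read by MTT assay, with a stated time of 72 h (a higher number here means a weaker inhibitor, a lower number a stronger inhibitor), compound 1 gives 619 nM. Compound 2 `CCOC(=O)c1ccccc1C(=O)OC1(C(=O)Nc2ccc([N+](=O)[O-])cc2)CCCCC1` carries an ethoxycarbonyl group at that carbon instead, and in this assay compound 2 gives 444 nM. The step of a 1.4-fold lower number from compound 1 to compound 2 (0.14 log units; within the scatter) lies within the scatter, so compound 2 holds the lowest of the two numbers without standing apart from compound 1.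

Compound 3 `O=C(OC1(C(=O)Nc2ccc([N+](=O)[O-])cc2)CCCCC1)c1ccccc1` has not yet been measured. Its difference from compound 2 is hydrogen in place of ethoxycarbonyl on an aromatic carbon. Going by the values given here, the only measured step touching this position is a 1.4-fold lower number from compound 1 to compound 2 (0.14 log units; within the scatter), which stayed within the scatter when iodo was exchanged for ethoxycarbonyl. Among the compounds with values here, no measured compound shows what a bare hydrogen at this carbon does. On that basis compound 3 is expected to give 500 nM in this assay, with a range from 200 nM to 1500 nM. The expected step is a 1.1-fold higher number from compound 2 to compound 3 (0.05 log units; within the scatter), that is, no change beyond the scatter in either direction.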

Compound 3, half-maximal inhibitory concentration: 903 nM
Estimate against measurement, compound 3: 1.8-fold (0.26 log units) below, within the range that was stated.
By their numbers in this assay, from the lowest: compounds 2, 1 and 3 (each within the scatter of the next, the first and the last beyond it).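

In this assay, the aromatic carbon ortho to a large group now shows a step beyond the scatter: hydrogen in place of ethoxycarbonyl gives (a 2.0-fold higher number from compound 2 to compound 3 (0.31 log units; beyond the scatter)), which is modest but separates the two groups in a way that the exchange of iodo for ethoxycarbonyl did not. Hydrogen in place of iodo gives (a 1.5-fold higher number from compound 1 to compound 3 (0.16 log units; within the scatter)), so these two groups cannot be told apart here, and iodo stays within the scatter of both hydrogen and ethoxycarbonyl; only the pair of hydrogen and ethoxycarbonyl stands apart, and by a small margin. Nothing available gives a reason for this step.

The compounds shown leave open whether the whole ethoxycarbonyl group is needed for the lower number or whether a shorter or different group at this carbon, such as methoxycarbonyl, a carboxylic acid or an amine, would give the same result. They also leave open how far the step from ethoxycarbonyl to hydrogen would hold if another part of the shared core were changed.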